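Trifluoromethyl for Ethoxy: Cytotoxicity in BJ Cells

The source may report more compounds than this note shows. Statements on the series, on what has been measured and on what is new or still open speak of the compounds shown alone.

Three measured compounds share one core and differ only in a single group on one aromatic ring. Compound 1 `CC(C)N(Cc1cccc(OCCCCCC(=O)O)c1)C(=O)c1ccc(-c2cccc(N(C)C)c2)cc1` was tested in an ADME assay on BJ cells (Homo sapiens) for cytotoxicity, read by CellTiter-Glo and resazurin assay, with a stated time of 72 h; a higher number here means that more compound is needed for the effect, a lower number that less compound is needed. In this assay compound 1 gives > 26000 nM, which is a limit of the assay and not a number. Compound 2 `CC(C)N(Cc1cccc(OCCCCCC(=O)O)c1)C(=O)c1ccc(-c2cccc(Oc3ccccc3)c2)cc1` carries phenoxy in place of dimethylamino on an aromatic carbon, and in this assay compound 2 gives > 18700 nM, again a limit. Compound 3 `CCOc1cccc(-c2ccc(C(=O)N(Cc3cccc(OCCCCCC(=O)O)c3)C(C)C)cc2)c1` carries ethoxy in place of dimethylamino on an aromatic carbon, and in this assay compound 3 gives > 20800 nM, also a limit. Because all three values are limits (the limit of > 18700 nM in this assay, at which 1 of the 3 values shown sits, (the limit of > 20800 nM in this assay, at which 1 of the 3 values shown sits), (the limit of > 26000 nM in this assay, at which 1 of the 3 values shown sits)), the steps a step that the two limits leave unreadable from compound 1 to compound 2, a step that the two limits leave unreadable from compound 1 to compound 3 and a step that the two limits leave unreadable from compound 2 to compound 3 cannot be sized, and compound 3 stands on the same footing as its two neighbours. Compound 4 `CC(C)N(Cc1cccc(OCCCCCC(=O)O)c1)C(=O)c1ccc(-c2cccc(C(F)(F)F)c2)cc1` differs from compound 3 by trifluoromethyl in place of ethoxy on an aromatic carbon. With no readable step among the measured compounds, the expected step is a step that the limit leaves unreadable from compound 3 to compound 4, that is, none beyond the scatter. Compound 4 is therefore estimated at 25000 nM, between 10000 nM and 80000 nM, and most probably reported only as a limit once more.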

Compound 4, half-maximal effective concentration: > 26000 nM
Compound 4 was reported as a limit; the forecaster's own chance of this, stated with the estimate: 80%; at least 1.0-fold (0.01 log units) between middle value and limit.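

Compound 4, like compound 1, compound 2 and compound 3, is reported only as a limit in this assay, and the steps linking compound 4 to the other three cannot be read. The compounds shown leave open whether these four groups differ in cytotoxicity at all.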